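Furan substituents in the series: chloro to hydroxymethyl

A few compounds are considered here, and "the series" means these few. Any claim that something is new, unique, unknown or untested is made for them only; others in the source may bear on it.

Measured in a functional assay on NCI-H460 cells (Homo sapiens) for cytotoxicity, read by MTT assay, with a stated time of 72 h (a lower number here means a stronger inhibitor, a higher number a weaker inhibitor), for each compound:
- compound 1 (`O=c1[nH]/c(=C\c2ncc[nH]2)c(=O)[nH]/c1=C\c1cccc(Oc2ccc(F)cc2)c1`) gives > 1000 nM which is a limit, not a number
- compound 2 (`O=c1[nH]/c(=C\c2ccco2)c(=O)[nH]/c1=C\c1cccc(Oc2ccc(F)cc2)c1`) gives 155 nM
- compound 3 (`O=c1[nH]/c(=C\c2ccc(Cl)o2)c(=O)[nH]/c1=C\c1cccc(Oc2ccc(F)cc2)c1`) gives 180 nM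

For the measured compounds named here, compound 3 lies within the scatter of compound 2, and its only other comparison is with the limit of compound 1. In compound 4 (`O=c1[nH]/c(=C\c2ccc(CO)o2)c(=O)[nH]/c1=C\c1cccc(Oc2ccc(F)cc2)c1`), hydroxymethyl stands in place of chloro on an aromatic carbon (hydroxymethyl in place of chloro on an aromatic carbon). The closest measured change is chloro in place of hydrogen, a 1.2-fold higher number from compound 2 to compound 3 (0.06 log units; within the scatter), which stays within the scatter. The larger steps, an at least 6.4-fold lower number from compound 1 to compound 2 (0.80 log units; beyond the scatter) and an at least 5.5-fold lower number from compound 1 to compound 3 (0.74 log units; beyond the scatter), replace the whole 1H-imidazol-2-yl and so are a different kind of change, though they show that this side of the molecule can matter. Hydroxymethyl itself has not been measured in this series, so the expectation is only a small move towards a higher number in this assay. The estimated step is a 1.7-fold higher number from compound 3 to compound 4 (0.22 log units; within the scatter) and the range is kept wide. Compound 4 is expected at 300 nM with an estimated range from 110 nM to 900 nM (expected, not measured).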

Compound 4, half-maximal inhibitory concentration: 41.5 nM
Compound 4: the middle estimate sits 7.2-fold (0.86 log units) above what was measured; the whole stated range lies above it.
By their numbers in this assay, from the lowest: compound 4; then compounds 2 and 3 (each within the scatter of the next). At a limit, above all of these: compound 1.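

In this assay, the aromatic carbon next to the ring oxygen can shift the read-out: chloro in place of hydrogen stayed within the scatter, whereas hydroxymethyl in place of hydrogen gives a 3.7-fold lower number from compound 2 to compound 4 (0.57 log units; beyond the scatter). Hydroxymethyl in place of chloro gives a 4.3-fold lower number from compound 3 to compound 4 (0.64 log units; beyond the scatter), so at this carbon the identity of the group matters, not only whether a group is present. Replacing 1H-imidazol-2-yl with the whole 5-(hydroxymethyl)furan-2-yl gives an at least 24-fold lower number from compound 1 to compound 4 (1.38 log units; beyond the scatter), a step that rests on a limit: the limit of > 1000 nM in this assay, at which 1 of the 4 values shown sits.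

The compounds shown do not separate the contribution of the hydroxyl oxygen from that of the added carbon; methyl, methoxymethyl or aminomethyl at this carbon would address that. On these data alone, it also remains open how a longer chain such as 2-hydroxyethyl, or a carboxylic acid, would read here.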